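Thiophene in place of pyridine on the anilino-pyrimidine series

The compounds below may be only part of what the source reports. "The series", "measured", "known", "first", "only" and "open" are said of these compounds alone.

Compound 1 `COc1ccc(Nc2nccc(-c3ccsc3)n2)cc1` and compound 2 `COc1ccc(Nc2nccc(-c3ccccn3)n2)cc1` share one core; compound 3 `Cc1cccc(Nc2nccc(-c3ccccn3)n2)c1` carries another, and the difference between the two cores is not broken down here. In a functional assay for inhibition, with Homo sapiens as the target (on this read-out higher numbers stand for weaker inhibition and lower numbers for stronger inhibition), compound 1 gives 15600 nM, compound 2 gives 8300 nM, and compound 3 gives 700 nM, the lowest of the three numbers, with compound 2 nearest to it and compound 1 furthest from it. The change thiophen-3-yl in place of pyridin-2-yl on an aromatic carbon made the step of a 1.9-fold higher number from compound 2 to compound 1 (0.27 log units; within the scatter). Compound 4 `Cc1cccc(Nc2nccc(-c3ccsc3)n2)c1` is not yet measured; it arises from compound 3 by thiophen-3-yl in place of pyridin-2-yl on an aromatic carbon, the same kind of change, the place differing only in that the group it is meta to counts 8 heavy atoms rather than 9. In this assay the step from compound 3 to compound 4 is expected at a 1.9-fold higher number from compound 3 to compound 4 (0.27 log units; within the scatter), set beside the earlier one, because the earlier pairing gave a 1.9-fold higher number from compound 2 to compound 1 (0.27 log units; within the scatter) and nothing else in the series speaks to this exchange. Compound 4 is accordingly estimated at 1300 nM, expected to fall between 500 nM and 3500 nM.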

Compound 4, half-maximal inhibitory concentration: 3800 nM
The estimate for compound 4 lay 2.9-fold (0.47 log units) below the measured number; the whole stated range lies below it.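

In this assay, thiophen-3-yl in place of pyridin-2-yl on the core of compound 3 gives a 5.4-fold higher number from compound 3 to compound 4 (0.73 log units; beyond the scatter), a step that lies beyond the scatter. The exchange therefore does not carry over from one core to the other at a fixed size, and the two steps differ by more than two such steps would scatter: the same change on two cores in this assay, a 1.9-fold higher number (0.27 log units; within the scatter) from compound 2 to compound 1 and a 5.4-fold higher number (0.73 log units; beyond the scatter) from compound 3 to compound 4, 2.9-fold (0.46 log units) apart, beyond the scatter of two such steps

This shows that a step within the scatter on the core of compound 1 cannot be assumed to stay there on the core of compound 3, but two pairs give no rule, and the difference between the two cores is not broken down, leaving no part of it tied to the size of the step.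

Still open, as far as these compounds go, is how another group at this place, such as phenyl, furan-3-yl or pyridin-3-yl, would behave on either core. Also open, from the compounds shown here alone, is whether an amine or a carboxylic acid elsewhere on the core of compound 3 would alter the size of this exchange.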